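Formyl to acetyl: the next step in the series

The source may hold more compounds than are shown below. What is called first, only, known or untested is meant among the compounds shown, and "the series" means these compounds.

Compound 3 (`O=C/C=C/n1c(=O)ccn([C@H]2C[C@H](O)[C@@H](CO)O2)c1=O`) gives 800 nM in a functional assay on HeLa cells (Homo sapiens) for inhibition (a higher number here means a weaker inhibitor, a lower number a stronger inhibitor), and sits in the middle of the three measured compounds. Compound 1 (`O=C/C=C/n1c(=O)c(I)cn([C@H]2C[C@H](O)[C@@H](CO)O2)c1=O`) lies lower at 300 nM and compound 2 (`Cc1cn([C@H]2C[C@H](O)[C@@H](CO)O2)c(=O)n(/C=C/CO)c1=O`) lies higher at 5000 nM in the same read-out.

The change methyl in place of hydrogen on a carbonyl carbon leads from compound 3 to compound 4 (`CC(=O)/C=C/n1c(=O)ccn([C@H]2C[C@H](O)[C@@H](CO)O2)c1=O`) and is methyl in place of hydrogen on a carbonyl carbon, so 2-formylethenyl becomes 2-acetylethenyl.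

Going by the values given here, no measured step touches this carbonyl carbon. Among the compounds with values here, the one single-place step available is a 2.7-fold higher number from compound 1 to compound 3 (0.43 log units; beyond the scatter) and it is modest, but it concerns hydrogen in place of iodo on an aromatic carbon. Compound 2 differs from compound 3 in more than one place, so compound 2 at 5000 nM cannot be read as a single step and offers only a weak hint on direction.

A small step toward a higher number is therefore expected in this assay on thin evidence. The expected step is a 1.9-fold higher number from compound 3 to compound 4 (0.27 log units; within the scatter) and this remains an estimate. The estimated value for compound 4 is 1500 nM and the expected range runs from 500 nM to 4500 nM on this estimate.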

Compound 4, half-maximal inhibitory concentration: 1500 nM
The estimate for compound 4 equals the measured number at the digits printed; low and high end bracket the measured number.
By their numbers in this assay, from the lowest: compound 1; then compounds 3 and 4 (each within the scatter of the next); then compound 2.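

Methyl in place of hydrogen on the carbonyl carbon gives a 1.9-fold higher number from compound 3 to compound 4 (0.27 log units; within the scatter) in this assay, so this step does not separate the formyl compound from the acetyl compound. Going by these compounds alone, the earlier single-place step, a 2.7-fold higher number from compound 1 to compound 3 (0.43 log units; beyond the scatter), concerned only an aromatic carbon and said nothing about the carbonyl end of the chain; this result adds the first reading at that carbonyl carbon and shows that, on the core of compound 3, 2-acetylethenyl in place of 2-formylethenyl leaves the read-out within the usual scatter. No measurement on these compounds accounts for this result, and the reading rests on a single pair.

As far as these compounds go, it remains open whether a longer chain on the carbonyl carbon, such as propanoyl, or a carboxylic acid or an amide at the same place would also stay within the scatter or would produce a clear step. Also open, from the compounds shown here alone, is whether iodo on the aromatic carbon, the change that separates compound 1 from compound 3, would give a similar step when the chain ends in acetyl.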